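A Cyclopropyl on the Carboxamide of Compound 1

The compounds below may be only part of what the source reports. "The series", "measured", "known", "first", "only" and "open" are said of these compounds alone.

Compound 1 `NC(=O)c1cnn2c1N(C(=O)Nc1cccc(F)c1)C(c1ccccc1)C2` is the starting point. In a functional assay on cells (Neutrophil, Homo sapiens) for inhibition, with a stated time of 10 min (on this read-out lower numbers stand for stronger inhibition and higher numbers for weaker inhibition), compound 1 gives 3.9 nM, the lowest number among the three measured compounds, and so it is the strongest inhibitor of this small set. Compound 2 `NC(=O)c1cnn2c1N(C(=O)Nc1ccc(F)cc1)C(c1ccccc1)C2` gives 11.4 nM in this assay, and compound 3 `NC(=O)c1cnn2c1N(C(=O)Nc1cccc3ccccc13)C(c1ccccc1)C2` gives 110 nM. The measured steps all change the group on the urea nitrogen: a 2.9-fold higher number from compound 1 to compound 2 (0.47 log units; beyond the scatter), a 28-fold higher number from compound 1 to compound 3 (1.45 log units; beyond the scatter) and a 9.6-fold higher number from compound 2 to compound 3 (0.98 log units; beyond the scatter).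

The step to compound 4 `O=C(NC1CC1)c1cnn2c1N(C(=O)Nc1cccc(F)c1)C(c1ccccc1)C2` touches a different place altogether: cyclopropyl in place of hydrogen on an amide-type nitrogen. Among the measured compounds shown here, no measured step changes this position, so the three known steps offer no direct guide. For the measured compounds named here, they show only that the numbers can move considerably when a group attached to the shared core is exchanged, which argues for caution rather than for any particular direction. For compound 4 the expected outcome is a modest step to a higher number, a 3.8-fold higher number from compound 1 to compound 4 (0.59 log units; beyond the scatter), with a broad margin on either side to reflect how little is known. Compound 4 is therefore estimated at 15 nM in this assay, within a range from 3 nM to 80 nM.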

Compound 4, half-maximal inhibitory concentration: 138 nM
Beside the measured number, compound 4's estimate is 9.2-fold (0.96 log units) below it, outside the stated range (above it).
By their numbers in this assay, from the lowest: compound 1; then compound 2; then compounds 3 and 4 (each within the scatter of the next).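

In this assay, replacing one amide hydrogen of compound 1 with cyclopropyl gives a 35-fold higher number from compound 1 to compound 4 (1.55 log units; beyond the scatter), so the carbamoyl group is a second place on the shared core where a single change moves the number by a large step. The earlier compounds shown here could not show this, as all their differences lay in the aryl group on the other amide-type nitrogen, while the carbamoyl group stayed the same throughout. Here, adding cyclopropyl on this nitrogen, which has the carbonyl carbon as its other neighbour, weakens inhibition rather than preserving the low number of compound 1, and no supporting measurement is available to explain why the step is so large.

On these data alone, it remains open whether this loss belongs to cyclopropyl itself or would follow any group on this nitrogen, a question that a methyl group, an ethyl group or a longer chain in the same place could help to answer. As far as these compounds go, it is also open how a nitrile or a carboxylic acid in place of the whole carbamoyl group would compare with compound 1, and whether the cyclopropyl change would have a step of similar size on compound 2.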